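This account rests on a few compounds, and the source may have more. Where it says the series, first, only, none or still open, it means among the compounds named here.

For the measured compounds named here, in an ADME assay on BJ cells (Homo sapiens) for cytotoxicity, with a stated time of 72 h (a higher number here means that more compound is needed for the effect, a lower number that less compound is needed), the three compounds measured so far all end at limits rather than numbers. Compound 1 `COc1cccc(-c2nc3c(c(C)nn3-c3ccccc3)c(-c3ccccc3O)c2C#N)c1` gives only a limit, > 23000 nM. Compound 2 `Cc1nn(-c2ccccc2)c2nc(-c3ccccc3)c(C#N)c(-c3ccccc3O)c12` also gives only a limit, > 23000 nM. Compound 3 `CCc1ccc(-c2nc3c(c(C)nn3-c3ccccc3)c(-c3ccccc3C#N)c2C#N)cc1`, the starting point here, likewise stands at a limit, > 20000 nM.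

Compound 4 `CCc1ccc(-c2nc3c(c(C)nn3-c3ccccc3)c(-c3ccccc3Br)c2C#N)cc1` differs from compound 3 in one place: bromo in place of cyano on an aromatic carbon. In words, the 2-cyanophenyl group becomes 2-bromophenyl. Going by the values given here, the only measured step, a step that the two limits leave unreadable from compound 1 to compound 2, involves a different change and gives no readable size to carry over. Among the compounds with values here, no measured step covers the exchange of cyano for bromo, so the evidence is limited to the limits themselves. On that basis, no step beyond the scatter is expected in this assay, and no direction can be assigned. The expected step is a step that the limit leaves unreadable from compound 3 to compound 4. Compound 4 is estimated at 23000 nM, with an expected range from 10000 nM to 50000 nM.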

Compound 4, half-maximal effective concentration: > 20000 nM
Compound 4 ended at the assay's limit (the forecaster's own chance of this, stated with the estimate: 80%); the middle value lies beyond the limit too.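

Compound 3 and compound 4 both end at limits in this assay, so the exchange of cyano for bromo between them cannot be read as a step. The compounds shown leave open how far any of the four lies beyond its limit.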